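Replacing the ester arm on a nucleoside-like core

A few compounds are considered here, and "the series" means these few. Any claim that something is new, unique, unknown or untested is made for them only; others in the source may bear on it.

Measured compounds:
compound 1, `CCOC(=O)Cn1c(=O)n(C2OC(CO)[C@@H](O)[C@H]2O)c2nc(N)nc(O)c21`, 86%
compound 2, `C=CCn1c(=O)n(C2C[C@H](O)C(CO)O2)c2nc(N)nc(O)c21`, 99%
compound 3, `C=CCSc1nc2c(O)nc(N)nc2n1C1OC(CO)[C@@H](O)[C@H]1O`, 107%

Three compounds have been run in a functional assay on the whole organism (B cells) with Mus musculus as the target; on this read-out higher numbers stand for larger maximal responses and lower numbers for smaller maximal responses. Compound 1 gives 86%, the lowest of the three numbers. Compound 2 stands higher, and compound 3 higher still, both gaps beyond the scatter of the read-out. Going by the values given here, compound 2 and compound 3 differ from compound 1 in more than one place, so no single step between them can be separated out; their values only show that a different substituent on the core goes with a larger maximal response.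

The unmeasured compound 4, `CCCCn1c(=O)n(C2OC(CO)[C@@H](O)[C@H]2O)c2nc(N)nc(O)c21`, is compound 1 with one change: propyl in place of ethoxycarbonyl on a saturated chain carbon bound to an aromatic nitrogen. Among the compounds with values here, no measured pair isolates this change, so any expectation for compound 4 rests on the three values alone.

Since the two compounds that carry a small hydrocarbon arm instead of the ester both sit above compound 1, the step from compound 1 to compound 4 in this assay is expected to be small and upward, about at the edge of the scatter, as a number 10 percentage points higher from compound 1 to compound 4 (within the scatter). For compound 4 the expected value is 96%, with a range from 82% to 110%.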

Compound 4, largest response reached (reported as maximal response), in percent of the reference or control that the assay uses: 86%
The estimate for compound 4 lay 10 percentage points above the measured number, within the range that was stated.
By their numbers in this assay, from the lowest: compounds 1 and 4 (each within the scatter of the next); then compounds 2 and 3 (each within the scatter of the next).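

In this assay, going by these compounds alone, putting propyl in place of ethoxycarbonyl on a saturated chain carbon bound to an aromatic nitrogen gives no change at the digits printed from compound 1 to compound 4 (within the scatter), the first step at this position that can be read on its own. In this pair the ester can therefore leave, and a plain hydrocarbon arm can take its place, without any larger maximal response appearing, so the change alone does not go with the higher numbers seen elsewhere in the series. No measurement shown offers an explanation for why the two arms read alike.

Going by these compounds, whether another arm at this carbon, such as an amine, a carboxylic acid or a longer chain, would shift the response in this assay remains open. The steps linking compound 2, at 99%, and compound 3, at 107%, to the other compounds cannot be read, and which of their differences from compound 1 goes with their higher numbers is still unresolved.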